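Aryl variation on the carbonyl carbon of the shared core

The compounds below may be only part of what the source reports. "The series", "measured", "known", "first", "only" and "open" are said of these compounds alone.

Compound 1 `COc1cc(C(=O)C2Sc3nnc(-c4cc(OC)c(OC)c(OC)c4)n3NC2c2ccco2)cc(OC)c1OC` is measured in a functional assay on A549 cells (Homo sapiens) for cytotoxicity, read by MTT assay, with a stated time of 48 h (a lower number here means a stronger inhibitor, a higher number a weaker inhibitor), and gives 48300 nM. Among the measured compounds shown here, compound 2 `COc1cc(-c2nnc3n2NC(c2ccco2)C(C(=O)c2ccc(O)cc2)S3)cc(OC)c1OC`, which carries 4-hydroxyphenyl in place of 3,4,5-trimethoxyphenyl on a carbonyl carbon, gives 93400 nM in this assay, so the only step known, a 1.9-fold higher number from compound 1 to compound 2 (0.29 log units; within the scatter), does not separate the two compounds.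

Compound 3 `COc1cccc(C(=O)C2Sc3nnc(-c4cc(OC)c(OC)c(OC)c4)n3NC2c2ccco2)c1` is not yet measured. It differs from compound 1 at the same place: 3-methoxyphenyl in place of 3,4,5-trimethoxyphenyl on a carbonyl carbon. For the measured compounds named here, the one step that bears on this change, a 1.9-fold higher number from compound 1 to compound 2 (0.29 log units; within the scatter), exchanges the aryl on the carbonyl carbon and stays within the scatter, which gives no reason to expect a shift beyond the scatter from compound 1 to compound 3 in this assay. The expected step is therefore small, a 1.2-fold higher number from compound 1 to compound 3 (0.09 log units; within the scatter), with the direction left open. For compound 3 the estimate in this assay is 60000 nM, with a range from 20000 nM to 180000 nM.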

Compound 3, half-maximal inhibitory concentration: > 100000 nM
Compound 3: a limit, no number (the forecaster's own chance of this, stated with the estimate: 10%); at least 1.6-fold (0.22 log units) between middle value and limit.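

In this assay compound 3 stands at a limit of the assay, > 100000 nM, and not at a number. Unlike the earlier step, this exchange on the carbonyl carbon gives a separation: 3-methoxyphenyl in place of 3,4,5-trimethoxyphenyl gives an at least 2.0-fold higher number from compound 1 to compound 3 (0.31 log units; beyond the scatter), so the aryl group at this place can matter in this assay. The exchange of 4-hydroxyphenyl for 3-methoxyphenyl gives an at least 1.0-fold higher number from compound 2 to compound 3 (0.02 log units; that floor lies within the scatter), and it cannot be read as a separation because only a floor exists for it: the limit of > 100000 nM in this assay, at which 1 of the 3 values shown sits.

Going by these compounds, how large the true step to compound 3 is stays open, as does any order between compound 2 and compound 3. Also open, on these data alone, is how an aryl group carrying an amine or a carboxylic acid would read on the same carbonyl carbon.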